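Methoxy for chloro on a fused ring with a triazole

This account rests on a few compounds, and the source may have more. Where it says the series, first, only, none or still open, it means among the compounds named here.

Compound 1: `COc1ccc2c(Cn3ccnc3)c(-c3ccc(F)cc3)[nH]c2c1` gives 109 nM
Compound 2: `Fc1ccc(-c2[nH]c3cc(Cl)ccc3c2Cn2cncn2)cc1` gives 96.9 nM

Both numbers come from an assay on isolated protein for inhibition of Aromatase (Homo sapiens), read by ELISA, using NADPH, with a stated time of 24 h; on this read-out lower numbers stand for stronger inhibition and higher numbers for weaker inhibition. Of the two measured compounds, compound 2 gives a number that differs from that of compound 1 only within the scatter, so neither can be called the stronger inhibitor. Compound 3, `COc1ccc2c(Cn3cncn3)c(-c3ccc(F)cc3)[nH]c2c1`, has not yet been measured. It differs from compound 2 by methoxy in place of chloro on an aromatic carbon. For the measured compounds named here, no measured pair isolates this change, so the step cannot be read off from the data. Compound 1 also carries the methoxy group on the shared core, and its number in this assay sits close to that of compound 2, which gives some ground to expect no step beyond the scatter. Compound 3 is therefore expected to fall near the two measured numbers, with an estimated value of 130 nM, ranging from 40 nM to 400 nM. The estimated step of a 1.3-fold higher number from compound 2 to compound 3 (0.13 log units; within the scatter) is expected to be small, if any.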

Compound 3, half-maximal inhibitory concentration: 238 nM
Compound 3: the middle estimate sits 1.8-fold (0.26 log units) below what was measured, within the range that was stated.
By their numbers in this assay, from the lowest: compounds 2 and 1 (each within the scatter of the next); then compound 3.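

In this assay, methoxy in place of chloro on an aromatic carbon of the shared core gives a 2.5-fold higher number from compound 2 to compound 3 (0.39 log units; beyond the scatter) and so counts as a modest change, which shows that this position is sensitive to the swap. For the compounds shown here, with the methoxy group held in place, 1H-1,2,4-triazol-1-yl in place of 1H-imidazol-1-yl on the saturated chain carbon gives a 2.2-fold higher number from compound 1 to compound 3 (0.34 log units; beyond the scatter) as a second modest change, so each single change moves the number beyond the scatter, which no earlier pair could show. The data offer no explanation for either step.

Still open, as far as these compounds go, is whether swapping chloro and methoxy has the same effect when 1H-imidazol-1-yl sits on the chain. Also open, from the compounds shown here alone, is how other groups on this aromatic carbon, such as an amine, a nitrile or a longer ethoxy chain, would compare.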